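Phenyl for Benzyl on an Amide-Type Nitrogen

A few compounds are considered here, and "the series" means these few. Any claim that something is new, unique, unknown or untested is made for them only; others in the source may bear on it.

Measured compounds:
compound 1, `O=c1ccc(-c2ccccc2)nn1CCCCNC(=S)NC1CCCCC1`: 18.1%
compound 2, `CC/N=C(/NC#N)NCCCCn1nc(-c2ccccc2)ccc1=O`: 58.8%
compound 3, `O=c1ccc(-c2ccccc2)nn1CCCCNC(=S)NCc1ccccc1`: 5.4%

All three share one core and differ only in the group at the far end of the chain. In a functional assay on the whole organism with Rattus norvegicus as the target, at a dose of 100 mg/kg (a higher number here means more inhibition at the dose given (going by the name of the read-out), a lower number less inhibition), compound 3 gives 5.4%, the lowest of the three numbers. Its nearest neighbour is compound 1, reached by the step of a number 12.7 percentage points lower from compound 1 to compound 3 (beyond the scatter); compound 2 lies furthest away, and the step of a number 40.7 percentage points higher from compound 1 to compound 2 (beyond the scatter) shows how large that gap is.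

Compound 4, `O=c1ccc(-c2ccccc2)nn1CCCCNC(=S)Nc1ccccc1`, has not yet been measured. It differs from compound 3 by phenyl in place of benzyl on an amide-type nitrogen. Within the data shown here, no measured step covers exactly this exchange: the step of a number 12.7 percentage points lower from compound 1 to compound 3 (beyond the scatter) also swaps a group on the same nitrogen and is modest, while the step of a number 40.7 percentage points higher from compound 1 to compound 2 (beyond the scatter) replaces a larger part of the molecule and is large. Because compound 3 gives 5.4% and the change is small, only a step of a number 6.6 percentage points higher from compound 3 to compound 4 (within the scatter) is expected, within the scatter. Compound 4 is therefore estimated to give about 12%, between 0% and 30%.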

Compound 4, a percentage reported as inhibition, in the whole organism at one dose (the size of the read-out at that dose, not a potency): 38.4%
Compound 4: the middle estimate sits 26.4 percentage points below what was measured; measured number above the stated range.
By their numbers in this assay, from the lowest: compound 3; then compound 1; then compound 4; then compound 2.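

In this assay, this nitrogen proves far more sensitive than the small change from benzylamino to anilino would suggest, with a number 33 percentage points higher from compound 3 to compound 4 (beyond the scatter) for phenyl in place of benzyl. Benzyl and phenyl each carry one six-membered aromatic ring, so having such a ring does not by itself set the number, and cyclohexyl falls between them, with a number 20.3 percentage points higher from compound 1 to compound 4 (beyond the scatter) on going to phenyl. Even phenyl does not reach the group carried by compound 2, as shown by a number 20.4 percentage points lower from compound 2 to compound 4 (beyond the scatter) for the larger exchange at the end of the chain.

As far as these compounds go, whether a chlorine on the phenyl ring or a longer phenethyl group would raise or lower the number remains open. No measured property is available to explain the size of these steps.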